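The source may report more compounds than this note shows. Statements on the series, on what has been measured and on what is new or still open speak of the compounds shown alone.

In a functional assay on DU-145 cells (Homo sapiens) for antiproliferative activity, read by MTT assay (on this read-out lower numbers stand for stronger inhibition and higher numbers for weaker inhibition), compound 3, `Cc1nn2c(-c3nc4cc(C(F)(F)F)ccc4[nH]3)c(-c3ccc(F)cc3)nc2s1`, stands lowest of the two numbers, giving 15800 nM. For the measured compounds named here, the nearest value belongs to compound 2, `Cc1nn2c(-c3nc4cc(C(F)(F)F)ccc4[nH]3)c(-c3ccccc3)nc2s1`, which gives 19600 nM; the one measured step, a 1.2-fold lower number from compound 2 to compound 3 (0.09 log units; within the scatter), is the swap of fluoro for hydrogen on an aromatic carbon and does not move the number beyond the scatter. Compound 1, `Cc1nn2c(-c3nc4c(C)c(C)ccc4[nH]3)c(-c3ccccc3)nc2s1`, carries methyl groups and no trifluoromethyl and reaches only the limit > 30000 nM, which is not a number. Going by the values given here, that limit, (the limit of > 30000 nM in this assay, at which 1 of the 3 values shown sits), is the only hint about methyl groups on this part of the core.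

Compound 4, `Cc1ccc2[nH]c(-c3c(-c4ccc(F)cc4)nc4sc(C)nn34)nc2c1`, differs from compound 3 by methyl in place of trifluoromethyl on an aromatic carbon. Among the compounds with values here, no measured step touches this position, so the expectation leans on compound 1 and its limit (the limit of > 30000 nM in this assay, at which 1 of the 3 values shown sits), with the scatter of the single measured step of a 1.2-fold lower number from compound 2 to compound 3 (0.09 log units; within the scatter) as the yardstick for what counts as a real change. For compound 4 the expected number is 25000 nM, with a range from 12000 nM to 50000 nM. The step this estimate means, a 1.6-fold higher number from compound 3 to compound 4 (0.20 log units; within the scatter), is expected toward weaker inhibition, possibly up to the limit of this assay.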

Compound 4, half-maximal inhibitory concentration: 19900 nM
For compound 4 the middle estimate is 1.3-fold (0.10 log units) above the measured one, within the range that was stated.
By their numbers in this assay, from the lowest: compounds 3, 2 and 4 (each within the scatter of the next). At a limit, above all of these: compound 1.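

In this assay, putting methyl in place of trifluoromethyl on the six-membered aromatic ring gives a 1.3-fold higher number from compound 3 to compound 4 (0.10 log units; within the scatter). For the compounds shown here, this is the first direct reading of this position, and it shows that, with the rest of compound 4 held the same as in compound 3, these two groups cannot be told apart here. Until now the only hint came from compound 1, which differs in more than one place and whose entry is a limit, not a number: the limit of > 30000 nM in this assay, at which 1 of the 4 values shown sits.

The compounds shown leave open whether any group at this position can move the number beyond the scatter, for instance an amine, a carboxylic acid or a longer chain. They also leave open whether the same swap reads alike when the fluoro on the other aromatic ring is replaced by hydrogen.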